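Solubility Outlook for Compound 4 Among Its Measured Neighbours

The compounds below may be only part of what the source reports. "The series", "measured", "known", "first", "only" and "open" are said of these compounds alone.

Compound 2 `CN1CCN(c2ncc(-c3ccc4c(N[C@@H]5CCCC[C@H]5O)ccnc4c3)cn2)CC1`: 980000 nM
Compound 3 `CN1CCN(c2ncc(-c3ccc4c(NC5CCC(N(C)C)CC5)ccnc4c3)cn2)CC1`: 660000 nM
Compound 1 `COc1ccc(NC(=O)c2ccc(-c3cnc(N4CCCN(C)CC4)nc3)cc2O)cc1Cl`: 6000 nM

In a physicochemical assay for solubility, read by LC-MS, measured as thermodynamic solubility, with a stated time of 24 h, at pH 7.4 (a higher number here means a more soluble compound, a lower number a less soluble compound), compound 2 gives the highest of the three numbers; compound 3 sits within the scatter of it, while compound 1 lies far lower. Compound 4 `CN1CCN(c2ncc(-c3ccc4c(NC5CCOCC5)ccnc4c3)cn2)CC1` is derived from compound 2 by the change (oxan-4-yl in place of 2-hydroxycyclohexyl on a nitrogen on an aromatic ring). Among the compounds with values here, the only measured step that bears on this change is a 1.5-fold lower number from compound 2 to compound 3 (0.17 log units; within the scatter), where a different group on the same nitrogen left the number within the scatter. The change to compound 4 keeps a six-membered non-aromatic ring and one hydrogen-bond acceptor while dropping the hydrogen-bond donor, so no step beyond the scatter is expected. Compound 4 is therefore estimated at 650000 nM, between 250000 nM and 1300000 nM, which amounts to an expected step of a 1.5-fold lower number from compound 2 to compound 4 (0.18 log units; within the scatter).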

Compound 4, solubility: 760000 nM
The estimate for compound 4 lay 1.2-fold (0.07 log units) below the measured number, and the stated range covers the measured number.
By their numbers in this assay, from the lowest: compound 1; then compounds 3, 4 and 2 (each within the scatter of the next).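

In this assay, oxan-4-yl in place of 2-hydroxycyclohexyl on this nitrogen gives a 1.3-fold lower number from compound 2 to compound 4 (0.11 log units; within the scatter) and oxan-4-yl in place of 4-(dimethylamino)cyclohexyl gives a 1.2-fold higher number from compound 3 to compound 4 (0.06 log units; within the scatter), so all three groups now lie within the scatter of one another. Compound 4 has neither the hydrogen-bond donor nor the 2 defined stereocentres of compound 2, yet its number stays within the scatter of that of compound 2. No evidence is available to explain this result. The compounds shown leave open whether a carboxylic acid or a longer open chain on this nitrogen would also stay within the scatter.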